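A few compounds are considered here, and "the series" means these few. Any claim that something is new, unique, unknown or untested is made for them only; others in the source may bear on it.

In a functional assay on MCF cells (Homo sapiens) for antiproliferative activity, with a stated time of 72 h (a higher number here means a weaker inhibitor, a lower number a stronger inhibitor), compound 1 (`Cc1ccc(CNc2ncnc3c2ncn3[C@@H]2O[C@H](CO)[C@@H](O)[C@H]2O)cc1`) gives > 166000 nM as a limit and not a number. Compound 2 (`COc1ccccc1CNc1ncnc2c1ncn2[C@@H]1O[C@H](CO)[C@@H](O)[C@H]1O`) likewise gives > 166000 nM as a limit only. Compound 3 (`OC[C@H]1O[C@@H](n2cnc3c(NCc4cccc(O)c4O)ncnc32)[C@H](O)[C@@H]1O`) at 5200 nM is the only one of the three with a true number, and it is the most potent of them. Compound 4 (`OC[C@H]1O[C@@H](n2cnc3c(NCc4cccc(C(F)(F)F)c4)ncnc32)[C@H](O)[C@@H]1O`) differs from compound 3 by 3-(trifluoromethyl)phenyl in place of 2,3-dihydroxyphenyl on a saturated chain carbon bound to a nitrogen on an aromatic ring and so gives up the 2,3-dihydroxyphenyl. For the measured compounds named here, two measured steps bear on this change: an at least 31-fold lower number from compound 1 to compound 3 (1.50 log units; beyond the scatter) and also an at least 31-fold lower number from compound 2 to compound 3 (1.50 log units; beyond the scatter) are both large and both bring in the 2,3-dihydroxyphenyl. Losing that group in compound 4 is therefore expected to give a large step towards a higher number in this assay and perhaps only a limit. The estimated step is a 17-fold higher number from compound 3 to compound 4 (1.24 log units; beyond the scatter) on this reasoning. Compound 4 is estimated at 90000 nM with a range from 20000 nM to 166000 nM as the expected span.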

Compound 4, half-maximal inhibitory concentration: > 166000 nM
Compound 4: no number, only a limit; the forecaster's own chance of this, stated with the estimate: 60%; middle value at least 1.8-fold (0.26 log units) from the limit.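

At the place on a saturated chain carbon bound to a nitrogen on an aromatic ring, this assay now gives an at least 31-fold higher number from compound 3 to compound 4 (1.50 log units; beyond the scatter), so 3-(trifluoromethyl)phenyl joins 2-methoxyphenyl and 4-methylphenyl in failing to keep the true number seen with the 2,3-dihydroxyphenyl. The value of compound 4 is a limit, and the steps between it and compound 1 or compound 2 cannot be read, so no order can be given among these three groups. Among the four compounds, only the 2,3-dihydroxyphenyl gives a true number, and the other three share one limit: the limit of > 166000 nM in this assay, at which 3 of the 4 values shown sit.

The compounds shown leave open whether both hydroxyl groups are needed, or whether a phenyl with a single hydroxyl would also give a true number. As far as these compounds go, whether an amine in place of the hydroxyl groups would do the same also stays open.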